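Removing a Methyl From a Weak Receptor Agonist

The compounds below may be only part of what the source reports. "The series", "measured", "known", "first", "only" and "open" are said of these compounds alone.

Of the compounds shown here, two have been tested so far in a functional assay on cells for agonist activity at Glucose-dependent insulinotropic receptor (Homo sapiens), read by a luciferase reporter, with a stated time of 4 h; on this read-out higher numbers stand for larger maximal responses and lower numbers for smaller maximal responses. Compound 1 `CS(=O)(=O)c1ccc2c(c1)CCN2c1ncnc2c(C3CCN(c4ncccn4)CC3)coc12` gives 196% in this assay. Compound 2 `Cn1cc(C2CCN(C(=O)OC(C)(C)C)CC2)c2ncnc(Nc3ccc(S(C)(=O)=O)cc3F)c21` gives 3% in this assay, the lower of the two numbers, lying far beneath compound 1 by a gap well beyond the usual scatter, so compound 2 produces almost no maximal response. Compound 3 `CC(C)(C)OC(=O)N1CCC(c2c[nH]c3c(Nc4ccc(S(C)(=O)=O)cc4F)ncnc23)CC1` has not yet been measured. It differs from compound 2 in one place: hydrogen in place of methyl on an aromatic nitrogen. Among the measured compounds shown here, compound 1 and compound 2 differ in many places at once, so no measured step shows what this single change does. Because compound 2 gives 3%, compound 3 is expected to stay near the bottom of the read-out, with only a small upward step expected a number 5 percentage points higher from compound 2 to compound 3 (within the scatter). The maximal response of compound 3 is estimated at 8%, within a range from 0% to 40%.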

Compound 3, largest response reached (Emax), in percent of the reference or control that the assay uses: 9%
Beside the measured number, compound 3's estimate is 1 percentage points below it; low and high end bracket the measured number.
By their numbers in this assay, from the lowest: compounds 2 and 3 (each within the scatter of the next); then compound 1.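

Hydrogen in place of methyl on an aromatic nitrogen now has its own measured step in this assay and that step reads a number 6 percentage points higher from compound 2 to compound 3 (within the scatter) so this single change does not separate the two compounds on this read-out. For this pair, then, the methyl on that nitrogen is not needed for the result seen with compound 2, and a hydrogen there does not bring a clear maximal response. Nothing measured here explains this result.

The compounds shown leave open whether a different group on this nitrogen, such as an ethyl, a longer chain or a chain ending in an amine, would give a clearly different response. Also open, as far as these compounds go, is whether the same swap would matter in a compound with a much larger maximal response.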